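The source may hold more compounds than are shown below. What is called first, only, known or untested is meant among the compounds shown, and "the series" means these compounds.

Of the compounds shown here, two from this series have been measured in a physicochemical assay for lipophilicity, in phosphate buffer, measured as octanol-water partition; a lower number here means a more polar compound, a higher number a more lipophilic compound. Compound 1 `O=c1c2ccccc2nc(-c2ccccc2)n1/N=C/c1ccc(Oc2ccc([N+](=O)[O-])cc2)cc1` gives 6.12 in this assay. Compound 2 `CCCc1nc2ccccc2c(=O)n1/N=C/c1ccc(Oc2ccc(Br)cc2)cc1` gives 5.88 in this assay, and these two values sit within the scatter of each other, so no order between them can be read. Compound 3 `CCCc1nc2ccccc2c(=O)n1/N=C/c1ccc(Oc2ccc([N+](=O)[O-])cc2)cc1` has not yet been measured. It differs from compound 2 in one place: nitro in place of bromo on an aromatic carbon. Among the measured compounds shown here, no measured pair shows this exact exchange, so the expectation rests on the change alone. The partition coefficient of compound 3 is expected to fall, a downward step of a number 0.48 log units lower from compound 2 to compound 3 (beyond the scatter) that would be beyond the scatter. Compound 3 is therefore estimated at 5.4, within a range from 4.8 to 6.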

Compound 3, partition coefficient: 5.18
Estimate against measurement, compound 3: 0.22 log units above, and the stated range covers the measured number.
By their numbers in this assay, from the lowest: compound 3; then compounds 2 and 1 (each within the scatter of the next).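

The earlier compounds shown here showed neither change alone. In this assay, nitro in place of bromo on the ring of the phenoxy group gives a number 0.70 log units lower from compound 2 to compound 3 (beyond the scatter) and is now seen as a step beyond the scatter, while propyl in place of phenyl on an aromatic carbon gives a number 0.94 log units lower from compound 1 to compound 3 (beyond the scatter) in the same direction. Nothing available here explains either step.

On these data alone, whether an amine or a carboxylic acid in place of nitro would give a lower number remains open. So does the effect of a longer chain in place of propyl.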